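Ring size at the thiocarbonyl and growth inhibition

A few compounds are considered here, and "the series" means these few. Any claim that something is new, unique, unknown or untested is made for them only; others in the source may bear on it.

Measured compounds:
- Compound 1 `Cc1ccnc(/C(N)=N/NC(=S)N2CCOCC2)c1`: 82.7%
- Compound 2 `N/C(=N\NC(=S)N1CCCC1)c1ccccn1`: 89.1%
- Compound 3 `Cc1ccnc(/C(N)=N/NC(=S)N2CCCCC2)c1`: 70.8%

The three compounds share a core that carries an amidine-linked thiosemicarbazide and differ in the saturated ring on the thiocarbonyl carbon. In a functional assay on HeLa cells (Homo sapiens) for cytotoxicity, read by MTT assay, with a stated time of 72 h, tested at 100 uM (on this read-out higher numbers stand for more inhibition of growth at the one concentration tested and lower numbers for less inhibition of growth), compound 3 stands lowest of the three; its nearest neighbour is compound 1, and compound 2 lies furthest from it. For the measured compounds named here, the one step that bears on the ring at this place is a number 11.9 percentage points lower from compound 1 to compound 3 (beyond the scatter), so exchanging one six-membered ring for another shifted the read-out by a modest amount beyond the scatter.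

Compound 4 `Cc1ccnc(/C(N)=N/NC(=S)N2CCCC2)c1` is not yet measured. It differs from compound 3 in one place: pyrrolidin-1-yl in place of piperidin-1-yl on a thiocarbonyl carbon. Compound 2 also carries a pyrrolidin-1-yl ring, though on a core without the methyl group, and its value is the highest shown. Since a single ring exchange at this carbon has already moved this assay by a modest step, a change of similar size is expected here, in the upward direction. For compound 4 the expected value is 81%, within 66% to 93%, which means a step of a number 10.2 percentage points higher from compound 3 to compound 4 (beyond the scatter) is expected.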

Compound 4, percent growth inhibition at one concentration: 88.1%
Compound 4: the middle estimate sits 7.1 percentage points below what was measured; low and high end bracket the measured number.
By their numbers in this assay, from the lowest: compound 3; then compounds 1, 4 and 2 (each within the scatter of the next).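

In this assay, pyrrolidin-1-yl in place of piperidin-1-yl on a thiocarbonyl carbon gives a number 17.3 percentage points higher from compound 3 to compound 4 (beyond the scatter) on the methyl-bearing core, which sets the piperidin-1-yl compound apart from the pyrrolidin-1-yl compound. Pyrrolidin-1-yl in place of morpholin-4-yl at the same carbon gives a number 5.4 percentage points higher from compound 1 to compound 4 (within the scatter) and so does not separate those two rings on this core. With pyrrolidin-1-yl held in place, methyl in place of hydrogen on an aromatic carbon gives a number 1 percentage points lower from compound 2 to compound 4 (within the scatter) and likewise makes no difference that this read-out can resolve.

Nothing at hand explains why the piperidin-1-yl compound stands apart. As far as these compounds go, it also remains open how an open-chain dimethylamino group, or a larger azepan-1-yl ring, would read at this thiocarbonyl carbon.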